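Esterifying a Ring Hydroxyl of Compound 1

The compounds below may be only part of what the source reports. "The series", "measured", "known", "first", "only" and "open" are said of these compounds alone.

Among the measured compounds shown here, compound 1 `C/C=C(\C)C(=O)O[C@H]1[C@]2(C)C[C@@H]3O[C@@]1(O)C=C1C4=CC(=O)O[C@@H](c5ccoc5)[C@]4(C)CC[C@@H]1[C@]3(C)[C@@H]2[C@@H](O)C(=O)OC` is the only compound here with a full number: in a functional assay on DU-145 cells (Homo sapiens) for inhibition, read by MTT assay, with a stated time of 24 h (a higher number here means a weaker inhibitor, a lower number a stronger inhibitor), compound 1 gives 7700 nM. Compound 2 `C/C=C(\C)C(=O)O[C@H]1[C@]2(C)C[C@@H]3O[C@@]1(O)C=C1C4=CC(=O)O[C@@H](c5ccoc5)[C@]4(C)CC[C@@H]1[C@]3(C)[C@@H]2C(=O)C(=O)OC` differs from it in one place, with (methoxycarbonyl)carbonyl in place of hydroxy(methoxycarbonyl)methyl on a saturated ring carbon. In this assay compound 2 reaches only a limit of the assay, > 100000 nM. For the measured compounds named here, the single measured step, an at least 12-fold higher number from compound 1 to compound 2 (1.11 log units; beyond the scatter), shows that losing that hydroxy of the side chain costs a great deal of activity, the value sitting at the limit of > 100000 nM in this assay, at which 1 of the 2 values shown sits.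

Compound 3 `C/C=C(\C)C(=O)O[C@@H]1[C@]2(OC(=O)CCCC)C=C3C4=CC(=O)O[C@@H](c5ccoc5)[C@]4(C)CC[C@@H]3[C@@]3(C)[C@H](C[C@]1(C)[C@H]3[C@@H](O)C(=O)OC)O2` has not been measured. It keeps the hydroxy(methoxycarbonyl)methyl side chain of compound 1 intact and changes a different position: butylcarbonyl in place of hydrogen on an oxygen on a saturated carbon. Going by the values given here, the one measured step concerns another hydroxy, so no measured step bears directly on this change, and the data give no reason to expect a large move in either direction. A step within the usual scatter is therefore expected, a 1.3-fold higher number from compound 1 to compound 3 (0.11 log units; within the scatter). In this assay compound 3 is estimated at 10000 nM, within a range of 3000 nM to 40000 nM.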

Compound 3, half-maximal inhibitory concentration: 5200 nM
The estimate for compound 3 lay 1.9-fold (0.28 log units) above the measured number; low and high end bracket the measured number.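

Turning the hydroxy into (butylcarbonyl)oxy adds a group of 6 heavy atoms, yet in this assay the step stays small: a 1.5-fold lower number from compound 1 to compound 3 (0.17 log units; within the scatter). This hydroxy, unlike the one on the side chain, can therefore carry this ester without a measurable loss of activity, which contrasts with the change to the side chain, where the step is large: an at least 12-fold higher number from compound 1 to compound 2 (1.11 log units; beyond the scatter). Nothing shown here explains why this position accepts the ester.

The compounds shown leave open whether this tolerance extends to other groups on the same oxygen, such as a shorter acetyl ester, a longer chain, or a chain ending in an amine or a carboxylic acid. They also leave open whether any group at this position can move activity beyond the usual scatter, and whether butylcarbonyl here would make any difference in a compound carrying the (methoxycarbonyl)carbonyl group of compound 2.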